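The source may hold more compounds than are shown below. What is called first, only, known or untested is meant among the compounds shown, and "the series" means these compounds.

Compound 1 `Cn1c(N)c(-c2nc3ccccc3[nH]2)c2nc(C#N)c(C#N)nc21` is the reference point. In a functional assay on HL-60 cells (Homo sapiens) for antiproliferative activity, read by MTT assay, with a stated time of 48 h (a lower number here means a stronger inhibitor, a higher number a weaker inhibitor), compound 1 reaches only the limit of the assay, > 50000 nM, so it is one of the values that sit at the limit of > 50000 nM in this assay, at which 1 of the 2 values shown sits. Compound 3 `N#Cc1nc2c(-c3nc4ccccc4[nH]3)c(N)n(CCCO)c2nc1C#N` differs from compound 1 by 2-hydroxyethyl in place of hydrogen on a saturated chain carbon bound to an aromatic nitrogen. Going by the values given here, one measured step bears on this change: compound 2 `N#Cc1nc2c(-c3nc4ccccc4[nH]3)c(N)n(CCN3CCCC3)c2nc1C#N` gives 4760 nM in this assay, and the move from compound 1 to compound 2, also on a saturated chain carbon bound to an aromatic nitrogen, was an at least 10-fold lower number from compound 1 to compound 2 (1.02 log units; beyond the scatter). A 2-hydroxyethyl is a different entering group, so a lower number is expected for compound 3 but of uncertain size. Compound 3 is therefore estimated at 15000 nM, between 4000 nM and 50000 nM, an expected step of an at least 3.3-fold lower number from compound 1 to compound 3 (0.52 log units; beyond the scatter).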

Compound 3, half-maximal inhibitory concentration: > 50000 nM
Compound 3 was reported as a limit; the forecaster's own chance of this, stated with the estimate: 35%; middle value at least 3.3-fold (0.52 log units) away from the limit.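

In this assay, compound 3, which carries 2-hydroxyethyl on a saturated chain carbon bound to an aromatic nitrogen, gives > 50000 nM, a limit of the assay. Exchanging pyrrolidin-1-yl for hydroxymethyl gives an at least 10-fold higher number from compound 2 to compound 3 (1.02 log units; beyond the scatter), so among the compounds shown, the readable value goes with the pyrrolidin-1-yl group and not with a chain alone. The step from compound 1 to compound 3 cannot be read, as both values are limits: the limit of > 50000 nM in this assay, at which 2 of the 3 values shown sit.

Going by these compounds, it remains open whether another amine, such as piperidine or morpholine, would keep or lower the number at this position. On these data alone, it also remains open how a carboxylic acid or a longer chain carrying pyrrolidin-1-yl would behave there.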